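Methoxy in Place of Fluoro on the Aryl Chain Carbon

The compounds below may be only part of what the source reports. "The series", "measured", "known", "first", "only" and "open" are said of these compounds alone.

Three measured compounds share one core: compound 1 `C=C(C/C(=C\c1ccccc1)C(=O)c1ccccc1)C(=O)c1ccccc1`, compound 2 `C=C(C/C(=C\c1ccc(F)cc1)C(=O)c1ccccc1)C(=O)c1ccccc1` and compound 3 `C=C(C/C(=C\c1ccccc1F)C(=O)c1ccccc1)C(=O)c1ccccc1`. In a functional assay on HBL-100 cells (Homo sapiens) for inhibition, read by sulforhodamine B assay, with a stated time of 48 h (on this read-out higher numbers stand for weaker inhibition of growth and lower numbers for stronger inhibition of growth), compound 1 gives 10000 nM, compound 2 gives 14000 nM and compound 3 gives 15000 nM, the largest of the three numbers, though the steps of a 1.5-fold higher number from compound 1 to compound 3 (0.18 log units; within the scatter) and a 1.1-fold higher number from compound 2 to compound 3 (0.03 log units; within the scatter) both lie within the scatter, as does a 1.4-fold higher number from compound 1 to compound 2 (0.15 log units; within the scatter). Compound 4 `C=C(C/C(=C\c1ccc(OC)cc1)C(=O)c1ccccc1)C(=O)c1ccccc1` has not yet been measured. The change is 4-methoxyphenyl in place of 2-fluorophenyl on a double-bonded chain carbon bound to a double-bonded chain carbon. The measured steps concern only a fluoro group being added or placed differently, none a methoxy group, so they speak only indirectly; what they show is that small changes on this ring left the number within the scatter. Compound 4 is therefore expected to show a 1.3-fold lower number from compound 3 to compound 4 (0.10 log units; within the scatter), no step beyond the scatter. Compound 4 is estimated at 12000 nM, between 6000 nM and 25000 nM.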

Compound 4, concentration for 50% growth inhibition: 530 nM
Compound 4: middle estimate off by 23-fold (1.35 log units), on the high side; the whole stated range lies above it.
By their numbers in this assay, from the lowest: compound 4; then compounds 1, 2 and 3 (each within the scatter of the next).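

In this assay, the group on a double-bonded chain carbon bound to a double-bonded chain carbon turns out to matter greatly: fluoro changes stayed within the scatter, but methoxy gives a 19-fold lower number from compound 1 to compound 4 (1.28 log units; beyond the scatter), a 26-fold lower number from compound 2 to compound 4 (1.42 log units; beyond the scatter) and a 28-fold lower number from compound 3 to compound 4 (1.45 log units; beyond the scatter). The large drop therefore appears against hydrogen as well as against fluoro, so among these compounds it goes with 4-methoxyphenyl alone. Nothing available explains this drop. The compounds shown leave open whether a hydroxy group, an ethoxy group or an amine in place of the methoxy would give a similarly low number.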